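A few compounds are considered here, and "the series" means these few. Any claim that something is new, unique, unknown or untested is made for them only; others in the source may bear on it.

Compound 1, `CC#CCn1c(N2CCC[C@@H](N)C2)cc(=O)n(Cc2ccc(Cl)c(C(=O)O)c2)c1=O`, gives 27.8% in an ADME assay on a cell-free system (plasma, Rattus norvegicus, strain Sprague-Dawley) for metabolic stability, read by LC-MS, with a stated time of 120 min, tested at 1 uM; a lower number here means that less of the compound is left, a higher number that more of the compound is left.
Compound 2, `CC#CCn1c(N2CCC[C@@H](N)C2)cc(=O)n(Cc2ccc(F)c(C(=O)OC)c2)c1=O`, gives 81.8% in this assay.
Compound 3, `CC#CCn1c(N2CCC[C@@H](N)C2)cc(=O)n(Cc2ccc(F)c(C(=O)O)c2)c1=O`, gives 22.5% in this assay.

Two of these three compounds differ in only one place. The change from compound 3 to compound 1 is chloro in place of fluoro on an aromatic carbon, and in this assay it made a step of a number 5.3 percentage points higher from compound 3 to compound 1 (within the scatter). The two cores on which this change sits differ by methyl in place of hydrogen on an oxygen next to a carbonyl group, and that difference alone made a step of a number 59.3 percentage points lower from compound 2 to compound 3 (beyond the scatter), so compound 2 stands highest of the three, beyond the scatter from both compound 1 and compound 3.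

Compound 4, `CC#CCn1c(N2CCC[C@@H](N)C2)cc(=O)n(Cc2ccc(Cl)c(C(=O)OC)c2)c1=O`, has not yet been measured in this assay. It differs from compound 2 by chloro in place of fluoro on an aromatic carbon. The place is not quite the same as in the measured pair: there the chloro entered ortho to a carboxy group (3 heavy atoms), here it enters ortho to a methoxycarbonyl group (4 heavy atoms), so it is the same kind of change rather than the same change. Going by the values given here, because the earlier step of a number 5.3 percentage points higher from compound 3 to compound 1 (within the scatter) lay within the scatter, the step from compound 2 to compound 4 is expected to be small as well, about a number 0.2 percentage points higher from compound 2 to compound 4 (within the scatter), with the only caveat that the evidence comes from a single pair on the other core. Compound 4 is therefore estimated to give 82% in this assay, most likely between 66% and 94%.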

Compound 4, percent of the compound remaining: 64.1%
Compound 4: middle estimate off by 17.9 percentage points, on the high side; measured number below the stated range.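

Chloro in place of fluoro on an aromatic carbon did not carry over unchanged from one core to the other in this assay: on the core with the methoxycarbonyl group it made a number 17.7 percentage points lower from compound 2 to compound 4 (beyond the scatter), and the comparison with the carboxy core shows that the two steps differ: the same change on two cores in this assay, a number 5.3 percentage points higher (within the scatter) from compound 3 to compound 1 and a number 17.7 percentage points lower (beyond the scatter) from compound 2 to compound 4, 23 percentage points apart, beyond the scatter of two such steps The methoxycarbonyl group in place of the carboxy group gave the higher number with either halogen, including a number 36.3 percentage points higher from compound 1 to compound 4 (beyond the scatter), but the size of this step was not the same with chloro as with fluoro: the same change on two cores in this assay, a number 59.3 percentage points lower (beyond the scatter) from compound 2 to compound 3 and a number 36.3 percentage points lower (beyond the scatter) from compound 4 to compound 1, 23 percentage points apart, beyond the scatter of two such steps These four compounds thus show that the two changes do not simply add up in this series, but they do not show why, and a single set of four cannot tell how either change would behave on any further core.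

The compounds shown leave open whether hydrogen, bromo or methyl in place of the halogen would follow the fluoro or the chloro compounds in this assay. They also leave open how an ethoxycarbonyl group or a primary amide in place of the methoxycarbonyl group would fare, and whether either would keep the higher numbers seen with the methoxycarbonyl group.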